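Neopentyl variant of the aminothiophene urea series

This account rests on a few compounds, and the source may have more. Where it says the series, first, only, none or still open, it means among the compounds named here.

Compound 3 `CC(C)CN1CCc2c(sc(NC(=O)Nc3ccc(Cl)cc3)c2C(N)=O)C1` gives the highest number of the three measured compounds in a functional assay (strain AB) with Danio rerio as the target, read by microscopy, with a stated time of 1 h (a lower number here means that less compound is needed, a higher number that more compound is needed for the effect), at 4510 nM. Compound 1 `CC(C)(C)OC(=O)CCCN1CCc2c(sc(NC(=O)Nc3ccc(Cl)cc3)c2C(N)=O)C1` gives 560 nM, and compound 2 `NC(=O)c1c(NC(=O)Nc2ccc(Cl)cc2)sc2c1CCN(C1CCOCC1)C2` gives 2830 nM. The gap a 1.6-fold higher number from compound 2 to compound 3 (0.20 log units; within the scatter) lies within the scatter, whereas an 8.1-fold higher number from compound 1 to compound 3 (0.91 log units; beyond the scatter) and a 5.1-fold higher number from compound 1 to compound 2 (0.70 log units; beyond the scatter) are modest and beyond it; the two more potent compounds share a larger substituent on the ring amine nitrogen.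

Compound 4 `CC(C)(C)CN1CCc2c(sc(NC(=O)Nc3ccc(Cl)cc3)c2C(N)=O)C1` differs from compound 3 only at the chain on that nitrogen: methyl in place of hydrogen on a saturated chain carbon bound to three saturated chain carbons. Cut one bond further out, this reads isobutyl to neopentyl. Going by the values given here, no measured step adds a single methyl on a saturated chain; the nearest comparison, oxan-4-yl to isobutyl, is within the scatter, and the only clearly active step, an 8.1-fold higher number from compound 1 to compound 3 (0.91 log units; beyond the scatter), involves the tert-butoxycarbonyl group, which compound 4 does not gain. A methyl alone is therefore expected to give a 1.1-fold higher number from compound 3 to compound 4 (0.04 log units; within the scatter), not beyond the scatter. The estimate for compound 4 in this assay is 5000 nM, within 2200 nM to 11000 nM.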

Compound 4, half-maximal effective concentration: 5560 nM
For compound 4 the middle estimate is 1.1-fold (0.05 log units) below the measured one, and the stated range covers the measured number.
By their numbers in this assay, from the lowest: compound 1; then compounds 2, 3 and 4 (each within the scatter of the next).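

In this assay, methyl in place of hydrogen on a saturated chain carbon bound to three saturated chain carbons gives a 1.2-fold higher number from compound 3 to compound 4 (0.09 log units; within the scatter), so this first single-methyl step on the chain leaves no readable change. Neopentyl in place of oxan-4-yl gives a 2.0-fold higher number from compound 2 to compound 4 (0.29 log units; within the scatter), while tert-butyl in place of 2-(tert-butoxycarbonyl)ethyl gives a 9.9-fold higher number from compound 1 to compound 4 (1.00 log units; beyond the scatter), which leaves compound 1 alone beyond the scatter of the other three. No supporting measurement bears on these steps.

As far as these compounds go, it remains open whether the number of compound 1 at 560 nM depends on the tert-butoxycarbonyl group itself or on the length of the chain. A carboxylic acid at the chain end, or a longer plain alkyl chain, would separate these two readings.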